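This account rests on a few compounds, and the source may have more. Where it says the series, first, only, none or still open, it means among the compounds named here.

Compound 1 `O=C(O)c1ccccc1-c1ccc(CCc2ncc(C3CCCCC3)[nH]2)cc1` gives 14.7 nM in an in vitro functional assay on cells for agonist activity at Bombesin receptor subtype-3 (Mus musculus), read by luminescence and calcium flux; on this read-out higher numbers stand for an effect only at larger amounts of compound and lower numbers for an effect already at smaller amounts.
Compound 2 `O=C(O)c1ccccc1-c1ccc(CCc2ncc(Cc3ccccc3Cl)[nH]2)cc1` gives 22 nM.
Compound 3 `CC(C)(C)Cc1cnc(CCc2ccc(-c3ccccc3C(=O)O)cc2)[nH]1` gives 6.3 nM.

Compound 3 shows the lowest number of the three. Its nearest neighbour is compound 1, with a 2.3-fold lower number from compound 1 to compound 3 (0.37 log units; beyond the scatter); compound 2 lies furthest away, with a 3.5-fold lower number from compound 2 to compound 3 (0.54 log units; beyond the scatter). The comparison of compound 1 with compound 2 shows a 1.5-fold higher number from compound 1 to compound 2 (0.18 log units; within the scatter).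

Compound 4 `CCC(C)(CC)Cc1cnc(CCc2ccc(-c3ccccc3C(=O)O)cc2)[nH]1` is the next compound, not yet measured. It differs from compound 3 in one place: 1-ethyl-1-methylpropyl in place of tert-butyl on a saturated chain carbon bound to an aromatic carbon. The shared core, the acid and the connecting chain are unchanged.

Among the compounds with values here, only the step to compound 3 from compound 2 concerns this saturated chain carbon, and it shows that a tert-butyl there is compatible with a low number. Within the data shown here, no measured pair tests enlarging the tert-butyl itself, so no step speaks directly to the change. The expected step from compound 3 to compound 4 is therefore a 1.1-fold lower number from compound 3 to compound 4 (0.02 log units; within the scatter), within the scatter. Compound 4 is estimated to give about 6 nM, expected to lie between 2.5 nM and 15 nM.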

Compound 4, half-maximal effective concentration: 30 nM
Beside the measured number, compound 4's estimate is 5.0-fold (0.70 log units) below it; the whole stated range lies below it.
By their numbers in this assay, from the lowest: compound 3; then compounds 1, 2 and 4 (each within the scatter of the next, the first and the last beyond it).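

Enlarging the tert-butyl on this saturated chain carbon bound to an aromatic carbon is not a neutral change: 1-ethyl-1-methylpropyl, with 6 heavy atoms in place of 4, gives a 4.8-fold higher number from compound 3 to compound 4 (0.68 log units; beyond the scatter) in this assay. The lead over the 2-chlorophenyl group disappears, with a 1.4-fold higher number from compound 2 to compound 4 (0.13 log units; within the scatter), and the lead over cyclohexyl is reversed, with a 2.0-fold higher number from compound 1 to compound 4 (0.31 log units; beyond the scatter). So the low number belongs to the tert-butyl itself and does not carry over to every larger branched alkyl group at this place.

No measurement here explains why the number rises. Still open, from the compounds shown here alone, is how 1,1-dimethylpropyl, which has one carbon more than tert-butyl, or a ring such as 1-methylcyclopropyl would behave at this place.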